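Swapping 2-cyanophenyl for furan-2-yl in a cytotoxicity series

The source may hold more compounds than are shown below. What is called first, only, known or untested is meant among the compounds shown, and "the series" means these compounds.

Of the compounds shown here, three have been measured in an ADME assay on J774.A1 cells (Mus musculus) for cytotoxicity, read by MTT assay, with a stated time of 72 h; on this read-out lower numbers stand for higher toxicity in this test and higher numbers for lower toxicity in this test. Compound 1 `CC1(Cc2ccccc2)CC(S(=O)(=O)c2cccc(C(F)(F)F)c2)=C(c2ccc(/C(N)=N\O)cc2)O1` gives 14500 nM. Compound 2 `CC1(c2ccc(-c3ccc(/C(N)=N\O)cc3)cc2)CC(S(=O)(=O)c2ccc(F)cc2)=C(c2ccc(/C(N)=N\O)cc2)O1` gives 3940 nM. Compound 3 `CC1(c2ccc(-c3ccccc3C#N)cc2)CC(S(=O)(=O)c2ccc(F)cc2)=C(c2ccc(/C(N)=N\O)cc2)O1` gives 9290 nM, the second highest of the three numbers; its value and that of compound 1 lie within the usual scatter of each other, whereas the step of a 2.4-fold higher number from compound 2 to compound 3 (0.37 log units; beyond the scatter) lies beyond it. Going by the values given here, that step is the only one between measured compounds that differ in a single place, and it altered the group on the aromatic carbon para to a large group, the same position that is changed in compound 4 `CC1(c2ccc(-c3ccco3)cc2)CC(S(=O)(=O)c2ccc(F)cc2)=C(c2ccc(/C(N)=N\O)cc2)O1`, where the change is furan-2-yl in place of 2-cyanophenyl on an aromatic carbon. In the measured step the larger group gave way to a smaller one and the number rose modestly; in the new step the group that enters is smaller again. Among the compounds with values here, with only that one step to rest on, the author expects the step of a 1.2-fold higher number from compound 3 to compound 4 (0.07 log units; within the scatter) to be small, at most modest, and if anything upward rather than downward. Compound 4 is therefore expected to give about 11000 nM in this assay, with a range from 4500 nM to 27000 nM.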

Compound 4, half-maximal cytotoxic concentration: 4560 nM
Beside the measured number, compound 4's estimate is 2.4-fold (0.38 log units) above it; measured number inside the range.
By their numbers in this assay, from the lowest: compounds 2 and 4 (each within the scatter of the next); then compounds 3 and 1 (each within the scatter of the next).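

In this assay the position on an aromatic carbon para to a large group now shows a reversal: a 2.0-fold lower number from compound 3 to compound 4 (0.31 log units; beyond the scatter) runs opposite in direction to a 2.4-fold higher number from compound 2 to compound 3 (0.37 log units; beyond the scatter), although a group with fewer heavy atoms enters in both steps. The heavy-atom count of the group at this position therefore does not order compound 2, compound 3 and compound 4, and the group with the fewest and the group with the most stand within the usual scatter of each other, with a 1.2-fold higher number from compound 2 to compound 4 (0.06 log units; within the scatter). Nothing at hand offers an explanation for this turn in direction or for the higher number of compound 3 alone among the three.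

From the compounds shown here alone, whether the higher number of compound 3 goes with the nitrile or with the six-membered ring that carries it stays open, and an unsubstituted phenyl group or a thiophen-2-yl group at this position would separate those readings. Going by these compounds, it is also open whether furan-2-yl in place of 2-cyanophenyl would give a step of the same direction and size with a sulfonyl group other than the one shared by these three compounds.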